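The source may hold more compounds than are shown below. What is called first, only, known or untested is meant among the compounds shown, and "the series" means these compounds.

Measured so far:
- Compound 1, `CCCCCCCCCCCCCCCNC(=O)[C@@H]1CSC(c2ccc(NC(C)=O)cc2)N1`: 1000 nM
- Compound 2, `CCCCCCCCCCCCCCCCCNC(=O)[C@@H]1CSC(c2ccc(NC(C)=O)cc2)N1`: 2400 nM
- Compound 3, `CCCCCCCCCCCCCCNC(=O)[C@@H]1CSC(c2ccccc2)N1`: 600 nM

The three measured compounds were tested in a functional assay on WM164 cells (Homo sapiens) for antiproliferative activity, read by sulforhodamine B assay, with a stated time of 48 h; on this read-out higher numbers stand for weaker inhibition and lower numbers for stronger inhibition. Compound 1 gives 1000 nM, and compound 2 gives 2400 nM. The step between them, a 2.4-fold higher number from compound 1 to compound 2 (0.38 log units; beyond the scatter), follows the change (ethyl in place of hydrogen on a saturated chain carbon, ten or more bonds along the chain from an amide-type nitrogen). Compound 3 carries a different core; the difference between the two cores is not broken down here. In this assay compound 3 gives 600 nM, which is the lowest of the three numbers, though its gap to compound 1 lies within the scatter, while its gap to compound 2 lies beyond it.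

Compound 4, `CCCCCCCCCCCCCCCCNC(=O)[C@@H]1CSC(c2ccccc2)N1`, has not yet been measured in this assay. It is related to compound 3 by ethyl in place of hydrogen on a saturated chain carbon, ten or more bonds along the chain from an amide-type nitrogen, which is the same change as that from compound 1 to compound 2, at the same place. That change was made twice among these compounds and only once with a measured result, so the one measured step is the sole guide. Compound 4 is therefore expected to show a 2.3-fold higher number from compound 3 to compound 4 (0.37 log units; beyond the scatter) in this assay. This expectation rests on a 2.4-fold higher number from compound 1 to compound 2 (0.38 log units; beyond the scatter), assumed to carry over to the second core. Compound 4 is accordingly estimated at about 1400 nM in this assay, within a range from 700 nM to 3000 nM.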

Compound 4, half-maximal inhibitory concentration: 700 nM
The estimate for compound 4 lay 2.0-fold (0.30 log units) above the measured number, within the range that was stated.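

In this assay, going by these compounds alone, the same ethyl-for-hydrogen change on the second core gave a 1.2-fold higher number from compound 3 to compound 4 (0.07 log units; within the scatter), so on this core the change produced no step that stands clear of the scatter. Set side by side, the two steps do not differ by more than the scatter allows: the same change on two cores in this assay, a 2.4-fold higher number (0.38 log units; beyond the scatter) from compound 1 to compound 2 and a 1.2-fold higher number (0.07 log units; within the scatter) from compound 3 to compound 4, 2.1-fold (0.31 log units) apart, within the scatter of two such steps. Within the data shown here, this shows that the step on the core of compound 1 and the step on the core of compound 3 cannot be told apart, so the result gives no firm sign that the core alters the effect of the change, but it does not show that the change carries over with one fixed size, for only one of the two steps lies beyond the scatter and two cores are a narrow basis for any rule.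

The compounds shown leave open how a longer chain would behave on either core, and whether the small steps seen here would grow, level off or reverse further along that series. They also leave open what a chain carrying an amine or a carboxylic acid would give in this assay, as every chain shown here is a plain saturated one.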